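This account rests on a few compounds, and the source may have more. Where it says the series, first, only, none or still open, it means among the compounds named here.

Measured so far:
Compound 1 `Cc1ccc(-c2cn(/N=C/c3cc4ccccc4nc3Cl)c(N)n2)cc1`. In a functional assay on DLD-1 cells (Homo sapiens) for cytotoxicity, read by MTT assay, with a stated time of 48 h (on this read-out lower numbers stand for stronger inhibition and higher numbers for weaker inhibition), compound 1 gives > 50000 nM, which is a limit of the assay and not a number.
Compound 2 `Cc1ccc2nc(Cl)c(/C=N/n3cc(-c4ccccc4)nc3N)cc2c1`. In this assay compound 2 gives 8790 nM.

Among the compounds with values here, compound 2 holds the only number; the other value sits at the limit of > 50000 nM in this assay, at which 1 of the 2 values shown sits. Compound 3 `Cc1ccc(-c2cn(/N=C/c3cc4cc(C)ccc4nc3Cl)c(N)n2)cc1` differs from compound 2 by methyl in place of hydrogen on an aromatic carbon. Compound 1 also carries the 4-methylphenyl and reaches only the limit of the assay. A step toward weaker inhibition, beyond the scatter, is expected: a 2.5-fold higher number from compound 2 to compound 3 (0.40 log units; beyond the scatter), with a real chance that only a limit is reported. Compound 3 is estimated at 22000 nM, between 7000 nM and 50000 nM.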

Compound 3, half-maximal inhibitory concentration: 25200 nM
For compound 3 the middle estimate is 1.1-fold (0.06 log units) below the measured one; low and high end bracket the measured number.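

Going from phenyl to 4-methylphenyl weakens inhibition in this assay, and the step is a 2.9-fold higher number from compound 2 to compound 3 (0.46 log units; beyond the scatter); a methyl para to a large group therefore carries a measurable cost here, yet compound 3 still gives a number. Compound 1 gives only a limit of the assay, not a number: the limit of > 50000 nM in this assay, at which 1 of the 3 values shown sits.
The second methyl of compound 3 reads as an at least 1.9-fold lower number from compound 1 to compound 3 (0.29 log units; that floor lies within the scatter), so this floor does not establish a gain.

Still open, from the compounds shown here alone, is whether methoxy, fluorine or an amine at this place would follow methyl. Going by these compounds, it is also open whether any replacement for the methyl would give a lower number than compound 2.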